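The source may report more compounds than this note shows. Statements on the series, on what has been measured and on what is new or still open speak of the compounds shown alone.

Compound 1: `N=C(S)CCCCCCN1N=C(c2ccccc2)CCC1=O`. In a functional assay on the whole organism (stomach) with Rattus norvegicus as the target (a higher number here means that more compound is needed for the effect, a lower number that less compound is needed), compound 1 gives 58.8 mg/kg.
Compound 2: `Cc1ccc(=O)n(C(C)CC(=N)S)n1`. For compound 2 this assay reports only a limit, > 100 mg/kg.

Compound 1 is the only one of the two with an actual number in this assay; the other value shown is a limit: the limit of > 100 mg/kg in this assay, at which 1 of the 2 values shown sits. Compound 3, `N=C(S)CCCN1N=C(c2ccccc2)CCC1=O`, has not yet been tested in this assay. It differs from compound 1 in one place: a group of 3 heavy atoms (1 carbon, 1 nitrogen, 1 sulfur; no ring) in place of a group of 6 heavy atoms (4 carbon, 1 nitrogen, 1 sulfur; no ring), on a saturated chain carbon, three bonds along the chain from an amide-type nitrogen in a ring. For the measured compounds named here, no step between measured compounds is available, so the size of the change from compound 1 to compound 3 in this assay cannot be read from any measured pair. Compound 3 is expected to sit close to compound 1 in this assay, with a somewhat larger dose estimated as more likely than a smaller one, so that the step of a 1.4-fold higher number from compound 1 to compound 3 (0.13 log units; within the scatter) is expected to lie near the edge of the scatter. The estimate for compound 3 is 80 mg/kg, within a range from 35 mg/kg to 200 mg/kg.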

Compound 3, dose for half-maximal effect: 100 mg/kg
For compound 3 the middle estimate is 1.3-fold (0.10 log units) below the measured one; measured number inside the range.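

For the compounds shown here, for the first time a step can be read at this position, on a saturated chain carbon: in this assay, the group of 3 heavy atoms in place of the group of 6 heavy atoms gives a 1.7-fold higher number from compound 1 to compound 3 (0.23 log units; within the scatter). Compound 1 and compound 3 therefore cannot be told apart in this assay, so this change at this position has no effect that stands clear of the usual scatter. Nothing shown gives a cause for this step.

Going by these compounds, it remains open whether a longer chain at this position would stay within the scatter of compound 1 or move beyond it. On these data alone, it is equally open how this assay would respond if an amine or a carboxylic acid took the place of the group at the end of the chain.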